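Swapping the amide aryl group on a shared naphthol core

The compounds below may be only part of what the source reports. "The series", "measured", "known", "first", "only" and "open" are said of these compounds alone.

Of the compounds shown here, two sharing one core have been measured so far. Compound 1 `O=C(Nc1cc(Sc2ncn[nH]2)c(O)c2ccccc12)c1ccc([N+](=O)[O-])cc1` carries a 4-nitrophenyl on the carbonyl carbon, and in a functional assay on PC-3 cells (Homo sapiens) for antiproliferative activity, read by MTT assay, with a stated time of 48 h (on this read-out higher numbers stand for weaker inhibition and lower numbers for stronger inhibition), compound 1 gives 53500 nM. Compound 2 `O=C(Nc1cc(Sc2ncn[nH]2)c(O)c2ccccc12)c1cccc(Cl)c1` carries a 3-chlorophenyl in that position, and in this assay compound 2 gives 85600 nM. Compound 2 stands at the upper end of these two numbers, but the gap, a 1.6-fold higher number from compound 1 to compound 2 (0.20 log units; within the scatter), lies within the usual scatter, so the two compounds cannot be told apart on potency.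

Compound 3 `COc1ccc(C(=O)Nc2cc(Sc3ncn[nH]3)c(O)c3ccccc23)cc1` differs from compound 2 by one change: 4-methoxyphenyl in place of 3-chlorophenyl on a carbonyl carbon. Among the compounds with values here, the only measured step that bears on this change is the one at the same position, a 1.6-fold higher number from compound 1 to compound 2 (0.20 log units; within the scatter), which stayed within the scatter when one aryl group replaced another. On that evidence an exchange of aryl groups here is expected to move this assay by no more than the scatter, in no firm direction. Compound 3 is therefore expected to give about 70000 nM, with a range from 30000 nM to 170000 nM, a step of a 1.2-fold lower number from compound 2 to compound 3 (0.09 log units; within the scatter) from compound 2.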

Compound 3, half-maximal inhibitory concentration: > 100000 nM
Compound 3 ended at the assay's limit; the forecaster's own chance of this, stated with the estimate: 20%; middle value at least 1.4-fold (0.15 log units) away from the limit.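

Compound 3 gives > 100000 nM in this assay, and this reading is a limit of the assay, not a number. Set against that limit, the change at the carbonyl carbon gives an at least 1.1-fold higher number from compound 2 to compound 3 (0.06 log units; that floor lies within the scatter), and the change on the aromatic carbon gives an at least 1.8-fold higher number from compound 1 to compound 3 (0.27 log units; that floor lies within the scatter); both are floors that lie within the scatter, so the result does not separate 4-methoxyphenyl from either of the other two aryl groups. What compound 3 adds to the earlier pair is that an aryl exchange at this position can carry the reading out of the range that the assay reports as a number, and it is the only one of the three compounds to do so: the limit of > 100000 nM in this assay, at which 1 of the 3 values shown sits.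

From the compounds shown here alone, how far the true value of compound 3 lies past the limit stays open, and with it the real size of both steps. Going by these compounds, all three compounds carry a substituted phenyl on the carbonyl carbon, so it also stays open how an unsubstituted phenyl, an aminophenyl or a longer alkyl chain in that place would read in this assay.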